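Methoxy at the para position of a quinazoline-like benzylamine

The source may hold more compounds than are shown below. What is called first, only, known or untested is meant among the compounds shown, and "the series" means these compounds.

Measured compounds:
Compound 1, `CSc1nc(NCc2ccc([Se]C)cc2)c2ccccc2n1`, gives > 100000 nM in a functional assay on HT-29 cells (Homo sapiens) for cytotoxicity, read by MTT assay, with a stated time of 72 h; on this read-out higher numbers stand for lower toxicity in this test and lower numbers for higher toxicity in this test.
Compound 2, `CSc1nc(NCc2ccccc2)c2ccccc2n1`, gives > 100000 nM in this assay.

Compound 2 sits at > 100000 nM, which is a limit of the assay and not a number. Both values shown so far are limits, as the limit of > 100000 nM in this assay, at which 2 of the 2 values shown sit, records, so the change from compound 1 to compound 2, a step that the two limits leave unreadable from compound 1 to compound 2, cannot be read in size or direction.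

Compound 3, `COc1ccc(CNc2nc(SC)nc3ccccc23)cc1`, is not yet measured. Among the compounds with values here, it differs from compound 2 by methoxy in place of hydrogen on an aromatic carbon, the only change being methoxy in place of hydrogen on an aromatic carbon. Within the data shown here, the one measured step, a step that the two limits leave unreadable from compound 1 to compound 2, also swaps a small group for hydrogen on an aromatic carbon. That step gives no readable size. On these numbers there is no reason to expect a step beyond the scatter in this assay, in either direction, and the assay may well return only a limit again. Compound 3 is therefore expected to give 150000 nM, with a range from 40000 nM to 500000 nM. The step this estimate means is a step that the limit leaves unreadable from compound 2 to compound 3, and it is expected to stay within the scatter.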

Compound 3, concentration lethal to 50% of the cells: > 100000 nM
Compound 3 ended at the assay's limit; the forecaster's own chance of this, stated with the estimate: 75%; the middle value is on the limit's open side.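

In this assay compound 3 gives > 100000 nM, which is a limit of the assay and not a number. No step between compound 1, compound 2 and compound 3 can be read, in size or in direction, because every value here is such a limit: the limit of > 100000 nM in this assay, at which 3 of the 3 values shown sit.

The compounds shown leave open whether methoxy in place of hydrogen changes the toxicity at all, and how toxic any of the three compounds actually is.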